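Taking the octyl chain off compound 3

A few compounds are considered here, and "the series" means these few. Any claim that something is new, unique, unknown or untested is made for them only; others in the source may bear on it.

Measured in a physicochemical assay for solubility, read by HPLC, at pH 7.4; on this read-out lower numbers stand for lower solubility and higher numbers for higher solubility:
- compound 1 `C=C(CCCCCCC)c1c(C)[nH]c2ccccc2c1=O`: < 2000 nM
- compound 2 `Cc1[nH]c2c(Cl)cccc2c(=O)c1Cc1ccccc1`: 5000 nM
- compound 3 `CCCCCCCCCc1c(C)[nH]c2cc(OC)c(Cl)cc2c1=O`: < 2000 nM

Compound 3 gives < 2000 nM, which is a limit and not a number. Compound 1 gives < 2000 nM, which is also a limit. Together these two make up (the limit of < 2000 nM in this assay, at which 2 of the 3 values shown sit). Only compound 2 gives a number, 5000 nM.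

Compound 4 `COc1cc2[nH]c(C)c(C)c(=O)c2cc1Cl` has hydrogen in place of octyl on a saturated chain carbon bound to an aromatic carbon. Among the measured compounds shown here, no measured pair isolates this change, and the limit for compound 3 leaves the starting point of the step open. An upward step in this assay, beyond the usual scatter, is nevertheless expected. Compound 2 carries no long saturated chain and gives 5000 nM. Compound 4 lacks such a chain too. That single value is the only support for the expectation, so the range is kept wide.

The expected change is an at least 10-fold higher number from compound 3 to compound 4 (1.00 log units; beyond the scatter). For compound 4 the estimate is 20000 nM, with an expected range of 4000 nM to 100000 nM.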

Compound 4, solubility: 5000 nM
Beside the measured number, compound 4's estimate is 4.0-fold (0.60 log units) above it; the measured number falls inside the stated range.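

In this assay, among the compounds shown here, hydrogen in place of octyl on a saturated chain carbon bound to an aromatic carbon gives an at least 2.5-fold higher number from compound 3 to compound 4 (0.39 log units; beyond the scatter), the first step that isolates a single place and can be read. From the compounds shown here alone, compound 3 gives < 2000 nM, which is a limit of the assay, so the printed step is a minimum and its full size stays unknown. With compound 4 this position now has a number on the read-out and no longer only a limit, and the direction of the change is established even though the start of the step remains unquantified, with the series otherwise sitting largely at one floor: the limit of < 2000 nM in this assay, at which 2 of the 4 values shown sit.

Only the two ends are shown at this position, octyl and hydrogen, so the course of the number along the chain stays open, and a butyl chain in the same place would show whether the change is gradual or sets in abruptly. Also open, going by these compounds, is whether an amine or a carboxylic acid at the end of a longer chain would keep the number in this assay clear of the limit that compound 3 carries.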